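Shortening the pentyl chain of compound 2

The source may report more compounds than this note shows. Statements on the series, on what has been measured and on what is new or still open speak of the compounds shown alone.

Values measured in an ADME assay on a cell-free system (plasma, Homo sapiens) for metabolic stability, read by LC-MS (a higher number here means that the compound lasts longer, a lower number that the compound disappears faster), are as follows
- compound 1 `CC(N)c1ccc(C(=O)Nc2ccncc2)cc1-c1ccc(F)cc1` gives > 2 h (a limit)
- compound 2 `CCCCCOC(=O)c1cccc(-c2cc(C(=O)Nc3ccncc3)ccc2CN)c1` gives 0.967 h
- compound 3 `NCc1ccc(C(=O)Nc2ccncc2F)cc1-c1cccc(C(=O)OCC2CCCC2)c1` gives 0.283 h

Of the two actual numbers, compound 2 has the higher one (0.967 h). Its nearest neighbour is compound 3 (0.283 h), a gap beyond the scatter. Compound 1 reads > 2 h and this is a limit of the assay, not a number.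

Compound 4 `COC(=O)c1cccc(-c2cc(C(=O)Nc3ccncc3)ccc2CN)c1` has not yet been measured. It differs from compound 2 in one place (hydrogen in place of butyl on a saturated chain carbon bound to an oxygen next to a carbonyl group), with hydrogen in place of butyl on a saturated chain carbon bound to an oxygen next to a carbonyl group, so that pentyloxycarbonyl becomes methoxycarbonyl.

Among the measured compounds shown here, no measured step isolates this change, so the expectation is tentative. It leans on compound 1 (> 2 h), which carries no such group. A moderate rise near the edge of the scatter is expected (a 1.9-fold higher number from compound 2 to compound 4 (0.27 log units; within the scatter)) in this assay and may reach the limit. Compound 4 is expected to give 1.8 h with an estimated range of 0.7 h to 4.5 h around that value.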

Compound 4, half-life: 1.52 h
For compound 4 the middle estimate is 1.2-fold (0.07 log units) above the measured one; the range from low to high includes it.
By their numbers in this assay, from the lowest: compound 3; then compounds 2 and 4 (each within the scatter of the next). At a limit, above all of these: compound 1.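

Among the compounds shown here, this is the first step that isolates the chain on the carbonyl-bound oxygen, with all else held the same: a 1.6-fold higher number from compound 2 to compound 4 (0.20 log units; within the scatter). Pentyloxycarbonyl and methoxycarbonyl therefore cannot be told apart in this assay, and at this place the loss of butyl, a piece of four carbon atoms, leaves no reading beyond the scatter. Both ends of the step are actual numbers, and neither compound sits at the limit of the assay: the limit of > 2 h in this assay, at which 1 of the 4 values shown sits.

Compound 1 and compound 3 each differ from compound 4 in more than one place, so neither isolates a further change at this position. The compounds shown leave open how a carboxylic acid or a primary amide in place of the methoxycarbonyl group, or a chain longer than pentyl, would read in this assay.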